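Working notes: allyloxy variation from compound 1 to compound 4

The compounds below may be only part of what the source reports. "The series", "measured", "known", "first", "only" and "open" are said of these compounds alone.

Compound 1 `C=CCOc1ccc(-c2c(C#N)c(N)nc(SCC(N)=O)c2C#N)cc1` carries the allyloxy group on the phenyl ring of the shared core; in an assay on CHO cells for displacement of a labelled ligand from adenosine receptor A1 (Homo sapiens), read by scintillation counting, with a stated time of 90 min (a higher number here means a weaker inhibitor, a lower number a stronger inhibitor), compound 1 gives 323 nM. Compound 2 `COC(=O)c1cccc(CSc2nc(N)c(C#N)c(-c3ccc(OCC4CC4)cc3)c2C#N)c1` gives 66 nM in this assay, and compound 3 `N#Cc1c(N)nc(SCc2ncc[nH]2)c(C#N)c1-c1ccc(OCC2CC2)cc1` gives 235 nM. Of the three numbers, that of compound 1 is the highest, though its difference from compound 3 lies within the scatter, while its difference from compound 2 lies beyond it. For the measured compounds named here, the single measured step, a 3.6-fold higher number from compound 2 to compound 3 (0.55 log units; beyond the scatter), concerns the group on the saturated chain carbon bound to the sulfur and leaves the alkoxy side of the core untouched.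

Compound 4 `C=C(C)COc1ccc(-c2c(C#N)c(N)nc(SCC(N)=O)c2C#N)cc1` differs from compound 1 only on that alkoxy side: methyl in place of hydrogen on a double-bonded chain carbon bound to a saturated chain carbon. Going by the values given here, no measured pair varies this place, so the step from compound 2 to compound 3 bears on it only as a general indication of how much the side chains move the number in this assay. Among the compounds with values here, with no direct precedent, no shift beyond the scatter is expected, and the expected step is a 1.1-fold lower number from compound 1 to compound 4 (0.03 log units; within the scatter). Compound 4 is therefore estimated at about 300 nM, within a range from 120 nM to 750 nM.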

Compound 4, inhibition constant: 872 nM
Compound 4: the middle estimate sits 2.9-fold (0.46 log units) below what was measured; measured number above the stated range.
By their numbers in this assay, from the lowest: compound 2; then compounds 3 and 1 (each within the scatter of the next); then compound 4.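

For the compounds shown here, the first measured step at this place is in this assay: replacing hydrogen with methyl on a double-bonded chain carbon bound to a saturated chain carbon gives a 2.7-fold higher number from compound 1 to compound 4 (0.43 log units; beyond the scatter) and weakens binding beyond the scatter. Going by these compounds alone, the alkoxy side of the shared core therefore responds to a change of a single heavy atom, which the earlier compounds could not show, since their only measured step lay on the saturated chain carbon bound to the sulfur. The comparison also shows that allyloxy and (2-methylprop-2-en-1-yl)oxy are not interchangeable here, at least with the sulfur-side group of compound 1 in place.

As far as these compounds go, it remains open whether an ethyl, a chlorine or a longer chain at this same carbon would raise the number as methyl does, or whether methyl is a special case. From the compounds shown here alone, it is also open whether the step would keep its size and direction with the 3-(methoxycarbonyl)phenyl or 1H-imidazol-2-yl group on the sulfur chain. No supporting measurement is available to explain why this methyl moves the number upward.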